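Inverting a Single Ring Stereocentre in an Iminosugar Acid

A few compounds are considered here, and "the series" means these few. Any claim that something is new, unique, unknown or untested is made for them only; others in the source may bear on it.

Compound 1, drawn as `O=C(O)[C@H]1NC[C@H](O)[C@@H](O)[C@H]1O`, is the reference point. In an assay for inhibition of alpha-N-acetylgalactosaminidase (Gallus gallus), tested at 1000 uM (on this read-out higher numbers stand for more inhibition at the one concentration tested (going by the name of the read-out) and lower numbers for less inhibition), compound 1 gives 31%, the highest of the three numbers measured. Compound 2 `O=C(O)[C@@H]1NC[C@H](O)[C@@H](O)[C@@H]1O` gives 3.4%, and compound 3 `O=C(O)[C@@H]1NC[C@H](O)[C@H](O)[C@H]1O` gives 4.4%. Both share every atom and bond with compound 1 and differ from it only in how two stereocentres are drawn. The step of a number 27.6 percentage points lower from compound 1 to compound 2 (beyond the scatter) and the step of a number 26.6 percentage points lower from compound 1 to compound 3 (beyond the scatter) run the same way, while the pair of compounds 2 and 3 show a number 1 percentage points higher from compound 2 to compound 3 (within the scatter). Compound 4, drawn as `O=C(O)[C@H]1NC[C@H](O)[C@@H](O)[C@@H]1O`, has not yet been measured. Relative to compound 1 the change is the two compounds have the same atoms and bonds and differ only in configuration as drawn: 1 of 4 stereo elements differ; a stereocentre at a saturated ring carbon is drawn S in compound 1 and R in compound 4. For the measured compounds named here, the measured steps described by the fact that compounds 1 and 2 differ only in the configuration as drawn and the fact that compounds 1 and 3 differ only in the configuration as drawn each involve two inverted centres, so neither isolates the effect of a single inversion, but both point downwards, and the one centre changed in compound 4 is among those changed in compound 2. The expectation for compound 4 is therefore a step downwards, a number 22 percentage points lower from compound 1 to compound 4 (beyond the scatter), beyond the scatter though possibly smaller than either measured step. Compound 4 is expected to give 9%, with a range from 2% to 25%.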

Compound 4, a percentage reported as inhibition, at one concentration (the size of the read-out at that concentration, not a potency): 0.2%
The estimate for compound 4 lay 8.8 percentage points above the measured number, and the stated range ends above it.
By their numbers in this assay, from the lowest: compounds 4, 2 and 3 (each within the scatter of the next); then compound 1.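

For the compounds shown here, a single inverted stereocentre is enough to remove nearly all the inhibition in this assay, and this is the first step here that isolates one centre, with a number 30.8 percentage points lower from compound 1 to compound 4 (beyond the scatter): the fact that compounds 1 and 4 differ only in the configuration as drawn Inverting a second centre on top of this one adds nothing that can be told apart, since compound 2 differs from compound 4 at one stereocentre only and the step is a number 3.2 percentage points lower from compound 2 to compound 4 (within the scatter). This centre is still not the only one that matters: compound 3 keeps it as drawn in compound 1 and differs from compound 4 at three centres, yet the step is only a number 4.2 percentage points lower from compound 3 to compound 4 (within the scatter), so inhibition can also be lost with this centre intact.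

Still open, going by these compounds, is whether inverting any other single stereocentre of compound 1 costs as much, and whether the low numbers of compounds 2, 3 and 4 hide real differences that this single-concentration read-out cannot separate. On these data alone, it is also open whether a methyl ester or an amide in place of the carboxylic acid, or a longer chain on the ring nitrogen, would keep the inhibition of compound 1.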